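The source may report more compounds than this note shows. Statements on the series, on what has been measured and on what is new or still open speak of the compounds shown alone.

Measured so far:
compound 1, `Cc1ccc(-c2noc(-c3ccc(C(=O)C(F)(F)F)s3)n2)cc1`, 860 nM;
compound 2, `O=C(c1ccc(-c2nc(-c3ccccn3)no2)s1)C(F)(F)F`, 500 nM;
compound 3, `Cc1cccc(-c2noc(-c3ccc(C(=O)C(F)(F)F)s3)n2)c1`, 680 nM.

In an assay on isolated protein for inhibition of protein deacetylase HDAC6 (Homo sapiens) (on this read-out higher numbers stand for weaker inhibition and lower numbers for stronger inhibition), compound 3 stands second highest of the three numbers. Its nearest neighbour is compound 1, with a 1.3-fold lower number from compound 1 to compound 3 (0.10 log units; within the scatter); the furthest is compound 2, with a 1.4-fold higher number from compound 2 to compound 3 (0.13 log units; within the scatter). Both of these gaps lie within the scatter, so the three compounds cannot be ranked against each other on this read-out.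

Compound 4, `O=C(c1ccc(-c2nc(-c3cccs3)no2)s1)C(F)(F)F`, has not yet been measured. It differs from compound 3 by one change: thiophen-2-yl in place of 3-methylphenyl on an aromatic carbon.

Every measured step in this set changes the group at this same position, and none of them moved the number beyond the scatter. The step of a 1.7-fold lower number from compound 1 to compound 2 (0.24 log units; within the scatter) replaced a carbon-only six-membered ring with a heteroaromatic ring, which is the closest analogy to the change from compound 3 to compound 4, and it stayed within the scatter, as did a 1.3-fold lower number from compound 1 to compound 3 (0.10 log units; within the scatter). Compound 4 is therefore expected to give a number close to that of compound 3, with the expected step being a 1.1-fold lower number from compound 3 to compound 4 (0.05 log units; within the scatter), not beyond the scatter in either direction. For compound 4 in this assay the estimate is 600 nM, with a range from 250 nM to 1500 nM.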

Compound 4, half-maximal inhibitory concentration: 670 nM
Compound 4: the middle estimate sits 1.1-fold (0.05 log units) below what was measured; the range from low to high includes it.
By their numbers in this assay, from the lowest: compounds 2, 4, 3 and 1 (each within the scatter of the next).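

Thiophen-2-yl is the only five-membered aromatic ring with 1 hetero atom among the groups shown on this aromatic carbon, between two ring nitrogen atoms, and in this assay its number stays within the scatter of all three others (a 1.0-fold lower number from compound 3 to compound 4 (0.01 log units; within the scatter); a 1.3-fold higher number from compound 2 to compound 4 (0.13 log units; within the scatter); a 1.3-fold lower number from compound 1 to compound 4 (0.11 log units; within the scatter)). The position therefore accepts a change of ring size and of ring atoms, from 7 heavy atoms in 3-methylphenyl to 5 in thiophen-2-yl with 1 sulfur, with no step beyond the scatter, and the four compounds still cannot be ranked against each other on this read-out. No measurement here bears on why the number stays so level across these groups.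

As far as these compounds go, all four groups at this position are aromatic rings, so it remains open whether an amine, a carboxylic acid or a longer alkyl chain on this carbon would move the number beyond the scatter. From the compounds shown here alone, it also remains open how far the number depends on the trifluoromethyl carbonyl group, which is the same in all four compounds.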